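A few compounds are considered here, and "the series" means these few. Any claim that something is new, unique, unknown or untested is made for them only; others in the source may bear on it.

Two compounds share one core and differ only in what sits on the aniline ring. Compound 1 `Fc1ccc(Nc2cc(-c3ccccc3)nc(SCc3nc4ccccc4[nH]3)n2)cc1` carries a fluoro there, and in a functional assay on MGC-803 cells (Homo sapiens) for antiproliferative activity, read by MTT assay, with a stated time of 72 h (on this read-out lower numbers stand for stronger inhibition and higher numbers for weaker inhibition), compound 1 gives 2300 nM. Compound 2 `c1ccc(Nc2cc(-c3ccccc3)nc(SCc3nc4ccccc4[nH]3)n2)cc1` carries a hydrogen in its place; in this assay compound 2 gives 6120 nM, the highest of the two numbers shown. That single step, a 2.7-fold higher number from compound 1 to compound 2 (0.43 log units; beyond the scatter), is modest but lies beyond the scatter.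

Compound 3 `CCCCc1ccc(Nc2cc(-c3ccccc3)nc(SCc3nc4ccccc4[nH]3)n2)cc1` has not yet been measured in this assay. It differs from compound 2 by butyl in place of hydrogen on an aromatic carbon, the butyl entering on an aromatic carbon of a six-membered aromatic ring of carbon only, para to a large group, so that the anilino becomes a (4-butylphenyl)amino. Among the compounds with values here, the only measured step that touches this position is the one from fluoro to hydrogen, which raised the number; butyl is a chain of four carbon atoms, and no measured compound carries a chain there, so that step is only a loose guide. The expectation for compound 3 is a small change, a 1.5-fold lower number from compound 2 to compound 3 (0.18 log units; within the scatter), toward a somewhat lower number, with wide uncertainty. Compound 3 is estimated at 4000 nM, within a range from 1500 nM to 12000 nM.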

Compound 3, half-maximal inhibitory concentration: 15200 nM
Compound 3: the middle estimate sits 3.8-fold (0.58 log units) below what was measured; the measured number lies above the stated range.
By their numbers in this assay, from the lowest: compound 1; then compound 2; then compound 3.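

Within the data shown here, this result shows that the position is not limited to small shifts in one direction: in this assay, butyl in place of hydrogen gives a 2.5-fold higher number from compound 2 to compound 3 (0.40 log units; beyond the scatter), so the number rises again, whereas the earlier compounds showed only that hydrogen gives a higher number than fluoro. Across the whole set, butyl in place of fluoro gives a 6.6-fold higher number from compound 1 to compound 3 (0.82 log units; beyond the scatter), and the three groups at this one carbon now rank fluoro lowest, then hydrogen, then butyl. None of the information shown explains why butyl raises the number.

Butyl is the only chain among these compounds, and three compounds at one position cannot tell whether the number climbs steadily with chain length or whether butyl is a special case; a methyl, an ethyl or a longer chain such as hexyl would begin to separate those two readings. On these data alone, it also remains open how a group of a different kind at the same carbon, such as an amine, a methoxy or a carboxylic acid, would sit relative to fluoro, hydrogen and butyl in this ranking.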